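Fluoro in place of hydrogen on compound 1

The source may hold more compounds than are shown below. What is called first, only, known or untested is meant among the compounds shown, and "the series" means these compounds.

In an ADME assay on the whole organism (Mus musculus, strain BALB/c) for pharmacokinetics, read by LC-MS, at a dose of 10 mg/kg by the oral route (on this read-out lower numbers stand for lower oral bioavailability and higher numbers for higher oral bioavailability), compound 1 (`COC(=O)NC12CCC(n3cc(-c4ccc(Cl)c(N)c4)c4c(N)ncnc43)(CC1)CC2`) gives 58% and compound 2 (`COC(=O)N[C@H]1CC[C@@H](n2cc(-c3ccc(Cl)c(N)c3)c3c(N)ncnc32)CC1`) gives 60% so the two lie within the scatter of each other. Compound 3 (`COC(=O)NC12CCC(n3cc(-c4cc(N)c(Cl)cc4F)c4c(N)ncnc43)(CC1)CC2`) is still unmeasured and differs from compound 1 by fluoro in place of hydrogen on an aromatic carbon. Among the measured compounds shown here, no measured pair shows this change, so no step beyond the scatter is expected in this assay in either direction. The estimated step of a number 3 percentage points lower from compound 1 to compound 3 (within the scatter) is expected to stay within the scatter. Compound 3 is expected at 55% with an estimated range of 35% to 75% in this series.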

Compound 3, oral bioavailability: 78%
The estimate for compound 3 lay 23 percentage points below the measured number; measured number outside the range, above it.
By their numbers in this assay, from the lowest: compounds 1 and 2 (each within the scatter of the next); then compound 3.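

In this assay, among the compounds shown here, fluoro in place of hydrogen on an aromatic carbon, ortho to a large group and para to an amino group, gives a number 20 percentage points higher from compound 1 to compound 3 (beyond the scatter), the only step beyond the scatter so far. This position therefore takes a fluoro group without loss on this read-out, and the number responds to a change at this carbon. Nothing measured here accounts for the rise.

From the compounds shown here alone, whether chloro, methyl or methoxy at this carbon would give a similar step remains open. So does whether fluoro would carry the same step on compound 2.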